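Moving the Halogen on the Sulfonyl Phenyl Ring

The compounds below may be only part of what the source reports. "The series", "measured", "known", "first", "only" and "open" are said of these compounds alone.

Of the compounds shown here, two sharing one core have been measured in an assay on isolated protein for inhibition of kallikrein-7 (Homo sapiens), read by fluorescence, with stated times of 10 min and 30 min; a higher number here means a weaker inhibitor, a lower number a stronger inhibitor. Compound 1 `CC1=NC(c2cn(S(=O)(=O)c3ccc(F)cc3)c3ccc(C)cc23)CN1` carries a 4-fluorophenyl on the sulfonyl sulfur, and in this assay compound 1 gives 9400 nM. Compound 2 `CC1=NC(c2cn(S(=O)(=O)c3cccc(Cl)c3)c3ccc(C)cc23)CN1` carries a 3-chlorophenyl in that place, and in this assay compound 2 gives 30000 nM, the higher of the two numbers, so compound 2 is the weaker inhibitor of the pair. Compound 3 `CC1=NC(c2cn(S(=O)(=O)c3ccccc3F)c3ccc(C)cc23)CN1` differs from compound 2 in that (2-fluorophenyl in place of 3-chlorophenyl on a sulfonyl sulfur). Going by the values given here, the only measured comparison that bears on this, a 3.2-fold higher number from compound 1 to compound 2 (0.50 log units; beyond the scatter), concerns the same ring on the same sulfur and shows that exchanging one substituted phenyl for another there shifts this assay by a modest amount. Compound 3 returns to a fluorine-bearing ring, now as 2-fluorophenyl, so a modest move toward a lower number than compound 2 is expected, tempered by the fact that this particular ring has not been tested. The expected step, a 2.0-fold lower number from compound 2 to compound 3 (0.30 log units; within the scatter), is an estimate only. Compound 3 is therefore estimated at 15000 nM, with a likely range from 5000 nM to 60000 nM.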

Compound 3, half-maximal inhibitory concentration: 4100 nM
Estimate against measurement, compound 3: 3.7-fold (0.56 log units) above; measured number below the stated range.
By their numbers in this assay, from the lowest: compound 3; then compound 1; then compound 2.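

Replacing 3-chlorophenyl with 2-fluorophenyl on the sulfonyl sulfur gives a 7.3-fold lower number from compound 2 to compound 3 (0.86 log units; beyond the scatter) in this assay and makes compound 3 the strongest inhibitor of the three. What the earlier pair could not show is that the number moves even when the halogen stays the same: with fluorine kept on the ring, 2-fluorophenyl in place of 4-fluorophenyl gives a 2.3-fold lower number from compound 1 to compound 3 (0.36 log units; beyond the scatter) and so the location of the fluorine on this ring matters by itself. Nothing measured here explains why these rings differ.

The step from 3-chlorophenyl to 2-fluorophenyl changes both the halogen and its location at once, so its size cannot be divided between the two, and a comparison with 3-fluorophenyl or 2-chlorophenyl would be needed to separate them. On these data alone, it also remains open how an unsubstituted phenyl, a methoxy group, a nitrile or an amine on this ring would read, and whether a ring is needed on the sulfur at all, as a simple methyl there would test.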